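A few compounds are considered here, and "the series" means these few. Any claim that something is new, unique, unknown or untested is made for them only; others in the source may bear on it.

Measured so far:
compound 1, `COc1cc(/C=C/C(=O)Oc2ccc(OCc3c(-c4ccccc4)no[n+]3[O-])cc2)ccc1O` — 31000 nM
compound 2, `O=C(/C=C/c1ccc(OCCCCCCO[N+](=O)[O-])c(O)c1)OCCCCCCO[N+](=O)[O-]` — > 50000 nM

In a functional assay on cells (Homo sapiens) for cytotoxicity, read by resazurin assay, with a stated time of 72 h (a lower number here means a stronger inhibitor, a higher number a weaker inhibitor), compound 1 gives 31000 nM. Compound 2 gives only a limit of the assay, > 50000 nM, and no number. That reading sits at the limit of > 50000 nM in this assay, at which 1 of the 2 values shown sits, so for compound 2 there is a bound and nothing more. Within the data shown here, no step between compound 1 and compound 2 is computed; the two values stand side by side as one number and one limit, and nothing more is drawn from the pair.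

Compound 3, `COc1cc(/C=C/C(=O)OCCCCCCO[N+](=O)[O-])ccc1OCCCCCCO[N+](=O)[O-]`, is not yet measured in this assay. It differs from compound 2 by methyl in place of hydrogen on an oxygen on an aromatic ring. The change is small, a single carbon entering, and the rest of compound 3 is unchanged from compound 2. Since compound 2 stands at a limit, the expected step from compound 2 to compound 3 is a step that the limit leaves unreadable from compound 2 to compound 3, nothing beyond the usual scatter. Compound 3 is therefore estimated at 60000 nM, with a range from 20000 nM to 200000 nM, and a limit rather than a number is the more likely outcome.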

Compound 3, half-maximal inhibitory concentration: > 50000 nM
Compound 3 was reported as a limit (the forecaster's own chance of this, stated with the estimate: 70%); the middle value lies beyond the limit too.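

Among these compounds, compound 2 and compound 3 both stand only as limits in this assay and so no step between them can be read: the limit of > 50000 nM in this assay, at which 2 of the 3 values shown sit. Still open, on these data alone, is whether methyl in place of hydrogen on an oxygen on an aromatic ring shifts the value in either direction, since neither compound gives a number.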